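Working notes: from compound 1 to compound 3

This account rests on a few compounds, and the source may have more. Where it says the series, first, only, none or still open, it means among the compounds named here.

Measured compounds:
compound 1 `COc1cc(/C=C/C(=O)c2cccc(-n3cc(-c4ccc(Cl)cc4)[nH]c3=O)c2)ccc1O` — 9610 nM
compound 2 `COc1cc(/C=C/C(=O)c2cccc(-n3cc(-c4ccccc4)[nH]c3=O)c2)ccc1O` — 3900 nM

In a functional assay on EKVX cells (Homo sapiens) for inhibition (a higher number here means a weaker inhibitor of growth, a lower number a stronger inhibitor of growth), compound 1 gives 9610 nM, the highest of the two numbers shown. The nearest is compound 2, which gives 3900 nM. Among the measured compounds shown here, the single measured step is a 2.5-fold lower number from compound 1 to compound 2 (0.39 log units; beyond the scatter).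

Compound 3 `O=C(/C=C/c1cccc(O)c1)c1cccc(-n2cc(-c3ccc(Cl)cc3)[nH]c2=O)c1` differs from compound 1 by 3-hydroxyphenyl in place of 4-hydroxy-3-methoxyphenyl on a double-bonded chain carbon bound to a double-bonded chain carbon. For the measured compounds named here, the one measured step concerns hydrogen in place of chloro on another aromatic carbon and gives no direct guide to this change; no other pair touches the 4-hydroxy-3-methoxyphenyl group. No step beyond the scatter is therefore expected in this assay, in either direction. Compound 3 is estimated at 9000 nM, with a range from 3000 nM to 27000 nM. This estimate corresponds to an expected 1.1-fold lower number from compound 1 to compound 3 (0.03 log units; within the scatter).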

Compound 3, concentration for 50% growth inhibition: 2400 nM
Compound 3: middle estimate off by 3.8-fold (0.57 log units), on the high side; measured number outside the range, below it.
By their numbers in this assay, from the lowest: compounds 3 and 2 (each within the scatter of the next); then compound 1.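

In this assay, the group on the double-bonded chain carbon also moves the number: 3-hydroxyphenyl in place of 4-hydroxy-3-methoxyphenyl gives a 4.0-fold lower number from compound 1 to compound 3 (0.60 log units; beyond the scatter), a change at a position the chloro step did not touch. The swap loses the methoxy and relocates the hydroxy at once, so the step cannot be assigned to either alteration. No measurement on hand accounts for the step.

Still open, going by these compounds, is whether the hydroxy is needed at all on this ring. An amine in its place remains untested among the compounds shown, and so does the effect of removing chloro alongside 3-hydroxyphenyl.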